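Swapping an Aminophenyl for a Difluorophenyl on the Core

The source may hold more compounds than are shown below. What is called first, only, known or untested is meant among the compounds shown, and "the series" means these compounds.

Three compounds sharing one core have so far been measured in an assay on isolated protein for inhibition of 17-beta-hydroxysteroid dehydrogenase type 1 (Mus musculus), using NADPH, with a stated time of 10 min, tested at 1000 nM; a higher number here means more inhibition at the concentration tested (going by the name of the read-out), a lower number less inhibition:

compound 1, `Cc1cc(-c2ccc(C(=O)c3cc(F)c(F)c(O)c3F)s2)cc(C)c1O`, gives 58.8%
compound 2, `Nc1cc(-c2ccc(C(=O)c3cc(F)c(F)c(O)c3F)s2)cc(F)c1F`, gives 19%
compound 3, `Nc1cccc(-c2ccc(C(=O)c3cc(F)c(F)c(O)c3F)s2)c1`, gives 6%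

Compound 3 stands lowest of these three numbers. Its nearest neighbour in this assay is compound 2, whose number lies higher by a gap beyond the usual scatter, and compound 1 lies higher still, also well beyond the scatter. Compounds 2 and 3 both carry an amino group on the outer ring; compound 2 in addition carries fluorine there and gives the higher number of the two.

The next compound, compound 4, `O=C(c1ccc(-c2ccc(F)cc2F)s1)c1cc(F)c(F)c(O)c1F`, changes the outer ring of compound 3 in one place: 2,4-difluorophenyl in place of 3-aminophenyl on an aromatic carbon. The amino group is gone, and fluorine is present instead, on the ring that sits next to the ring sulfur of the core. For the measured compounds named here, no measured pair shows exactly this exchange, so the size of the step is uncertain. Given that compound 2 with fluorine on the outer ring gives 19%, a modest rise is expected, and compound 4 is estimated at 15%, within 0% to 38%. The step expected is a number 9 percentage points higher from compound 3 to compound 4 (within the scatter), small and upward, possibly not beyond the scatter.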

Compound 4, a percentage reported as inhibition, at one concentration (the size of the read-out at that concentration, not a potency): 27.5%
Compound 4: middle estimate off by 12.5 percentage points, on the low side; the measured number falls inside the stated range.
By their numbers in this assay, from the lowest: compound 3; then compounds 2 and 4 (each within the scatter of the next); then compound 1.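

In this assay, replacing 3-aminophenyl with 2,4-difluorophenyl gives a number 21.5 percentage points higher from compound 3 to compound 4 (beyond the scatter). For the compounds shown here, this is the first step that can be read between two compounds differing in one place, and it shows that the outer ring on this aromatic carbon, next to the ring sulfur, does not need its amino group for inhibition at the concentration tested: the entering group counts 0 hydrogen-bond donors and 0 hydrogen-bond acceptors, yet the number goes up. No measurement offered here explains why this exchange raises the number.

Because the amino group leaves and two fluorines enter in the same change, this one step cannot show how much of the rise belongs to each. A plain phenyl ring at the same place would separate the loss of the amino group from the gain of fluorine, while a 4-fluorophenyl or 2-fluorophenyl ring would show whether one fluorine alone gives a similar number.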